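This account rests on a few compounds, and the source may have more. Where it says the series, first, only, none or still open, it means among the compounds named here.

Measured compounds and their values in an ADME assay on Huh-7 cells (Homo sapiens) for cytotoxicity, with a stated time of 72 h; on this read-out lower numbers stand for higher toxicity in this test and higher numbers for lower toxicity in this test:

Compound 1 `CC(C)CCn1nc(-c2cccs2)c(O)c(C2=NS(=O)(=O)c3cc(NS(=O)(=O)C4CC4)ccc3N2)c1=O` gives > 1000 nM, which is a limit of the assay rather than a number.
Compound 2 `CC(C)CCn1nc(CC(C)C)c(O)c(C2=NS(=O)(=O)c3cc(NS(C)(=O)=O)ccc3N2)c1=O` gives > 1000 nM, again a limit of the assay.
Compound 3 `CCC(C)(C)Cn1nc(-c2cccs2)c(O)c(C2=NS(=O)(=O)c3cc(NS(C)(=O)=O)ccc3N2)c1=O` gives > 1000 nM, also a limit of the assay.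

Compound 3 therefore stands nowhere in particular on these numbers: its result in this assay is a limit, and the same holds for the two other compounds, since all three sit at the limit of > 1000 nM in this assay, at which 3 of the 3 values shown sit. For the measured compounds named here, no compound here has been told apart from another by this test, and no step between measured compounds is available.

Compound 4 `CS(=O)(=O)Nc1ccc2c(c1)S(=O)(=O)N=C(c1c(O)c(-c3cccs3)nn(CCC3CCCCC3)c1=O)N2` has not yet been measured in this assay. It differs from compound 3 in one place: cyclohexylmethyl in place of 1,1-dimethylpropyl on a saturated chain carbon bound to an aromatic nitrogen. With every measured value being a limit, no step beyond the usual scatter is expected; the step that the limit leaves unreadable from compound 3 to compound 4 is expected to stay within that scatter, most likely with another limit reported. Compound 4 is expected to give about 2500 nM in this assay, within a range from 1000 nM to 10000 nM.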

Compound 4, half-maximal cytotoxic concentration: > 17000 nM
Compound 4 gave a limit, no number; the forecaster's own chance of this, stated with the estimate: 85%; middle value at least 6.8-fold (0.83 log units) away from the limit.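

In this assay, for the compounds shown here, compound 3 and compound 4 both give limits rather than numbers, and no step between them can be read. The compounds shown leave open the actual concentration at which any of them harms these cells, and whether cyclohexylmethyl in place of 1,1-dimethylpropyl changes it.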